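Fluoro for Methyl on the Aryl Ring of Compound 3

A few compounds are considered here, and "the series" means these few. Any claim that something is new, unique, unknown or untested is made for them only; others in the source may bear on it.

Measured compounds:
- compound 1 `O=C1N/C(=N\c2nccs2)S/C1=C\c1cccc(O)c1`: 33.7%
- compound 2 `COc1cc(/C=C2\S/C(=N\c3nccs3)NC2=O)cc(OC)c1O`: 39%
- compound 3 `Cc1ccc(/C=C2\S/C(=N/c3nccs3)NC2=O)cc1`: 47%

Three compounds sharing one core were tested in a functional assay on the whole organism (strain AKR) for inhibition, with Mus musculus as the target, read by paw edema, with a stated time of 3.5 h, at a dose of 0.01 mmol/kg by the intraperitoneal route; a lower number here means less inhibition, a higher number more inhibition at the dose given (going by the name of the read-out). Compound 1 gives 33.7%, compound 2 gives 39%, and compound 3 gives 47%. Compound 3 holds the highest of the three numbers; its gap to compound 2 lies within the scatter, so no order between those two can be claimed, while its gap to compound 1 lies beyond the scatter.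

Compound 4 `O=C1N/C(=N\c2nccs2)S/C1=C\c1ccc(F)cc1` is not yet measured in this assay. It differs from compound 3 by a single exchange: fluoro in place of methyl on an aromatic carbon. Among the measured compounds shown here, no pair of measured compounds shows what such a one-atom swap does here, so the size of the step rests on expectation alone. Because compound 3 gives 47%, a step from compound 3 to compound 4 of a number 5 percentage points lower from compound 3 to compound 4 (within the scatter) is expected, small and within the scatter, with a slight lean downward. Compound 4 is therefore estimated at 42% in this assay, with a range from 28% to 56%.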

Compound 4, a percentage reported as inhibition, in the whole organism at one dose (the size of the read-out at that dose, not a potency): 65.6%
The estimate for compound 4 lay 23.6 percentage points below the measured number; the whole stated range lies below it.
By their numbers in this assay, from the lowest: compounds 1, 2 and 3 (each within the scatter of the next, the first and the last beyond it); then compound 4.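

In this assay, among the compounds shown here, fluoro in place of methyl on an aromatic carbon, para to a large group, gives a number 18.6 percentage points higher from compound 3 to compound 4 (beyond the scatter) and is the only one-place step in this set. It shows that this position is not indifferent to a one-atom exchange, even though neither group carries hydrogen-bond donors, hydrogen-bond acceptors or a net charge. Nothing measured here accounts for the size of this step.

The compounds shown leave open how plain hydrogen on this carbon would read against fluoro and methyl, and whether chloro, trifluoromethyl or an amine there would move the number further. They also leave open whether the same exchange would give a similar step on the hydroxy-bearing ring of compound 1 or the more heavily substituted ring of compound 2.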